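This account rests on a few compounds, and the source may have more. Where it says the series, first, only, none or still open, it means among the compounds named here.

Three measured members of the series share one core. Compound 1 `CCC(CC)Nc1nc(C)nc2c(-c3c(C)cc(N(C)C)nc3C)c(C)nn12`, compound 2 `CCCCC(C)Nc1nc(C)nc2c(-c3ccc(OC)nc3C)c(C)nn12` and compound 3 `CCCCN(CC)c1nc(C)nc2c(-c3ccc(OC)nc3C)c(C)nn12` have been tested in an assay on cell membranes for displacement of a labelled ligand from corticotropin-releasing factor receptor 1 (Rattus norvegicus); a higher number here means a weaker inhibitor, a lower number a stronger inhibitor. Compound 1 gives 25.6 nM, the highest of the three numbers; compound 2 gives 5.1 nM and compound 3 gives 4.9 nM, each beyond the scatter from compound 1. For the measured compounds named here, the only single-site step among the measured compounds, a 1.0-fold lower number from compound 2 to compound 3 (0.02 log units; within the scatter), puts butyl(ethyl)amino in place of (1-methylpentyl)amino on an aromatic carbon and leaves the number where it was.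

Compound 4 `CCCCN(CC)c1nc(C)nc2c(-c3c(C)cc(N(C)C)nc3C)c(C)nn12` is not yet measured. It differs from compound 1 in one place: butyl(ethyl)amino in place of (pentan-3-yl)amino on an aromatic carbon. The rest of compound 4 matches compound 1 exactly. The step from compound 2 to compound 3 is the only one that bears on this change: the same entering group, butyl(ethyl)amino, replaced a branched alkylamino there and gave no shift beyond the scatter. On that basis no step beyond the scatter is expected in this assay for compound 4, in either direction. For compound 4 the expected value is 25 nM. The expected lower end for compound 4 is 10 nM. The expected upper end for compound 4 is 60 nM. The step this estimate means is expected to be a 1.0-fold lower number from compound 1 to compound 4 (0.01 log units; within the scatter).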

Compound 4, half-maximal inhibitory concentration: 32.8 nM
Compound 4: middle estimate off by 1.3-fold (0.12 log units), on the low side; low and high end bracket the measured number.
By their numbers in this assay, from the lowest: compounds 3 and 2 (each within the scatter of the next); then compounds 1 and 4 (each within the scatter of the next).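

In this assay, butyl(ethyl)amino in place of (pentan-3-yl)amino gives a 1.3-fold higher number from compound 1 to compound 4 (0.11 log units; within the scatter), so this change leaves the number in place on the core of compound 1, even though the entering group has no hydrogen-bond donor and the leaving group has one. Read with a 1.0-fold lower number from compound 2 to compound 3 (0.02 log units; within the scatter), this shows butyl(ethyl)amino matching a branched alkylamino at this position, on an aromatic carbon between two ring nitrogen atoms, in two pairs: one with the dimethylamino-bearing aryl group of compound 1 and compound 4, the other with the methoxy-bearing aryl group of compound 2 and compound 3. No measured evidence explains why the number holds in either pair.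

On these data alone, these two pairs cover only open-chain alkylamino groups, so it remains open whether a cyclic amine such as morpholine or pyrrolidine, or an ether-bearing chain such as bis(2-methoxyethyl)amino, would hold the number at this position. It is also open whether a much shorter chain, such as dimethylamino, or a longer one, such as dibutylamino, would stay within the scatter of these compounds.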